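Ortho-substituent swap on the arylhydrazone: iodo to trifluoromethyl

This account rests on a few compounds, and the source may have more. Where it says the series, first, only, none or still open, it means among the compounds named here.

Working notes on the series whose shared core is that of compound 1 `CC1CC/C(=N\Nc2ccc(F)cc2)c2ncc(C(=O)O)c(=O)n21`. All data come from a functional assay on the whole organism for inhibition, with Rattus norvegicus as the target; a lower number here means that less compound is needed, a higher number that more compound is needed for the effect. Compound 1 gives only a limit here, > 1000 umol/kg. Compound 2 `CC1CC/C(=N\Nc2ccccc2Br)c2ncc(C(=O)O)c(=O)n21` likewise gives only a limit, > 320 umol/kg. Compound 3 `CC1CC/C(=N\Nc2ccccc2I)c2ncc(C(=O)O)c(=O)n21` also gives only a limit, > 1000 umol/kg. Within the data shown here, compound 3 therefore stands at the limit of > 1000 umol/kg in this assay, at which 2 of the 3 values shown sit, and no measured compound in the set has a number rather than a limit.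

The steps among the measured compounds are all unreadable: a step that the two limits leave unreadable from compound 1 to compound 2, a step that the two limits leave unreadable from compound 1 to compound 3 and a step that the two limits leave unreadable from compound 2 to compound 3. The step from compound 3 to compound 4 `CC1CC/C(=N\Nc2ccccc2C(F)(F)F)c2ncc(C(=O)O)c(=O)n21` is trifluoromethyl in place of iodo on an aromatic carbon. The nearest measured step is the one in which iodo replaced bromo on the same aromatic carbon, and it too is unreadable, the two values sitting at the limit of > 320 umol/kg in this assay, at which 1 of the 3 values shown sits, and (the limit of > 1000 umol/kg in this assay, at which 2 of the 3 values shown sit). Among the measured compounds shown here, nothing measured so far gives a direction or a size for an exchange of halogen for trifluoromethyl on this ring.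

The expectation for compound 4 is therefore only that it will most likely again sit at a limit. The step expected is a number no higher from compound 3 to compound 4 (the limit leaves the size open). The estimate for compound 4 in this assay is 1000 umol/kg, with a range from 300 umol/kg to 3000 umol/kg.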

Compound 4, dose for 50% inhibition: > 1000 umol/kg
Compound 4: no number, only a limit (the forecaster's own chance of this, stated with the estimate: 80%); the middle value sits exactly at the limit.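

In this assay compound 4 gives only a limit, > 1000 umol/kg. The steps to compound 4 from compound 3 and from compound 2 cannot be read, with limits at both ends of each. The compounds shown leave open whether any exchange of substituent on this aromatic ring changes the dose needed, and in which direction.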